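The source may hold more compounds than are shown below. What is called first, only, known or untested is meant among the compounds shown, and "the series" means these compounds.

Working notes on the series. In a functional assay on HL-60 cells (Homo sapiens) for activation, read by flow cytometry, with a stated time of 4 days (a lower number here means that less compound is needed, a higher number that more compound is needed for the effect), compound 2 `COc1ncc(-n2cnc3cnc(-c4ccc(F)cc4C)cc32)cn1` gives 2900 nM. Compound 3 `Fc1ccc(-c2cc3c(cn2)ncn3-c2ccc(OC(F)F)cc2)cc1` gives 10000 nM in this assay, the highest of the two numbers shown, and the step from compound 2 is beyond the scatter. Compound 1 `Cc1cc(F)ccc1-c1cc2c(cn1)ncn2-c1ccc(O)nc1` in this assay reaches only the limit > 10000 nM, a limit and not a number (the limit of > 10000 nM in this assay, at which 1 of the 3 values shown sits). For the measured compounds named here, the one step measured on the group on the aromatic nitrogen is an at least 3.4-fold lower number from compound 1 to compound 2 (0.53 log units; beyond the scatter).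

Compound 4 `Cc1cccc(C)c1-c1cc2c(cn1)ncn2-c1ccc(OC(F)F)cc1` differs from compound 3 on the aromatic carbon: 2,6-dimethylphenyl in place of 4-fluorophenyl on an aromatic carbon. Going by the values given here, no measured step touches that position, so the step from compound 1 to compound 2 gives no guide to the size or direction here. With compound 3 already at 10000 nM, the step to compound 4 is expected to stay within the scatter; the estimated step is a 1.3-fold lower number from compound 3 to compound 4 (0.10 log units; within the scatter). Compound 4 is therefore expected at 8000 nM in this assay, with a range from 2000 nM to 30000 nM.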

Compound 4, half-maximal effective concentration: 980 nM
Estimate against measurement, compound 4: 8.2-fold (0.91 log units) above; measured number below the stated range.
By their numbers in this assay, from the lowest: compound 4; then compound 2; then compound 3.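

In this assay, the aromatic carbon next to the ring nitrogen proves to be a position at which the number responds strongly, with the group on the aromatic nitrogen held unchanged: a 10-fold lower number from compound 3 to compound 4 (1.01 log units; beyond the scatter). For the compounds shown here, until now, the only step lay on that nitrogen, so this is the first reading of the change on the aromatic carbon. The two groups do not differ in their counts of hydrogen-bond donors, hydrogen-bond acceptors or net charge, so the step comes without any change in those counts. Nothing at hand bears on why this change lowers the number.

The compounds shown leave open whether the step depends on both methyl groups, on one of them or on the loss of the fluorine. Going by these compounds, it also remains open how larger ethyl groups, or an amine or a carboxylic acid on this phenyl ring, would read.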